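A few compounds are considered here, and "the series" means these few. Any claim that something is new, unique, unknown or untested is made for them only; others in the source may bear on it.

Measured compounds:
Compound 1, `Fc1cccc(NCn2nc(-c3ccc4c(c3)OCCO4)oc2=S)c1`, 6620 nM in a functional assay, with a stated time of 6 min; on this read-out higher numbers stand for weaker inhibition and lower numbers for stronger inhibition.
Compound 2, `FC(F)(F)c1cccc(NCn2nc(-c3ccc4c(c3)OCCO4)oc2=S)c1`, 7620 nM in this assay.

Among these two numbers compound 1 has the lower one, and its only neighbour is compound 2, with a 1.2-fold higher number from compound 1 to compound 2 (0.06 log units; within the scatter). Compound 3, `S=c1oc(-c2ccc3c(c2)OCCO3)nn1CNc1ccc(Cl)c(Cl)c1`, differs from compound 1 by 3,4-dichlorophenyl in place of 3-fluorophenyl on an amine nitrogen. Going by the values given here, the single measured step, the replacement of fluoro by trifluoromethyl, does not touch a 3,4-dichlorophenyl group, so no step bears directly on this change; the one step seen stays within the scatter. In this assay compound 3 is therefore expected to give 6000 nM, between 2500 nM and 15000 nM, a step of a 1.1-fold lower number from compound 1 to compound 3 (0.04 log units; within the scatter).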

Compound 3, half-maximal inhibitory concentration: 6840 nM
Compound 3: middle estimate off by 1.1-fold (0.06 log units), on the low side; low and high end bracket the measured number.
By their numbers in this assay, from the lowest: compounds 1, 3 and 2 (each within the scatter of the next).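

In this assay, the change on the amine nitrogen from 3-fluorophenyl to 3,4-dichlorophenyl gives a 1.0-fold higher number from compound 1 to compound 3 (0.01 log units; within the scatter). The earlier step concerned only trifluoromethyl in place of fluoro, whereas this one brings in chlorine at two ring places, and the read-out still stays within the scatter. Nothing at hand offers an explanation for this result.

As far as these compounds go, it remains open whether the number would respond to a different group on this nitrogen, such as a pyridine ring, a phenyl ring carrying a carboxylic acid or an amine, or a plain alkyl chain.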